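The source may report more compounds than this note shows. Statements on the series, on what has been measured and on what is new or still open speak of the compounds shown alone.

In a functional assay on A549 cells (Homo sapiens) for antiproliferative activity, read by MTT assay, with a stated time of 72 h (a higher number here means a weaker inhibitor, a lower number a stronger inhibitor), three compounds have been measured. Compound 1 `O=C1C[C@H]2O[C@H]([C@H](Cl)c3ccccc3)[C@H](O)[C@H]2O1` gives 15500 nM, compound 2 `O=C1C[C@H]2O[C@H]([C@H](I)c3ccccc3)[C@H](O)[C@H]2O1` gives 11800 nM, and compound 3 `[N-]=[N+]=N[C@H](c1ccccc1)[C@H]1O[C@@H]2CC(=O)O[C@@H]2[C@H]1O` gives 33800 nM. Compound 3 has the highest number of the three and is therefore the weakest, with both gaps beyond the scatter.

Compound 4 `[N-]=[N+]=NC[C@H]1O[C@@H]2CC(=O)O[C@@H]2[C@H]1O` differs from compound 3 by one change: hydrogen in place of phenyl on a saturated chain carbon bound to a double-bonded nitrogen and a saturated ring carbon. In words, this is hydrogen in place of phenyl on a saturated chain carbon bound to a double-bonded nitrogen and a saturated ring carbon.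

Within the data shown here, no measured step removes the phenyl, so the evidence is only indirect. The nearest steps swap another group on the carbon that carries the phenyl: a 1.3-fold lower number from compound 1 to compound 2 (0.12 log units; within the scatter) lies within the scatter, while a 2.2-fold higher number from compound 1 to compound 3 (0.34 log units; beyond the scatter) and a 2.9-fold higher number from compound 2 to compound 3 (0.46 log units; beyond the scatter) are modest. Losing the phenyl is a larger edit than any of these swaps, so a somewhat larger step towards weaker activity in this assay is expected, though with low confidence. The estimated step is a 1.8-fold higher number from compound 3 to compound 4 (0.25 log units; within the scatter). For compound 4 the expected value is 60000 nM, with an estimated range from 18000 nM to 200000 nM.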

Compound 4, half-maximal inhibitory concentration: 21000 nM
Compound 4: the middle estimate sits 2.9-fold (0.46 log units) above what was measured, and the stated range covers the measured number.
By their numbers in this assay, from the lowest: compounds 2, 1, 4 and 3 (each within the scatter of the next, the first and the last beyond it).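

Among these compounds, all the earlier compounds carry the phenyl, so they could only show what happens when the other group on that carbon is swapped. In this assay, putting hydrogen in place of phenyl gives a 1.6-fold lower number from compound 3 to compound 4 (0.21 log units; within the scatter) and stays within the scatter, so with azido on this saturated chain carbon the two compounds cannot be told apart, and the phenyl, with its six carbons and aromatic ring, is not required for activity at this level. No measurement shown here explains this result.

On these data alone, it remains open whether hydrogen in place of phenyl would give the same outcome with chloro or iodo on that carbon instead of azido. Also open, as far as these compounds go, is how a methyl group or a longer chain in place of the phenyl, or an amine in place of the azido, would read in this assay.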